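This account rests on a few compounds, and the source may have more. Where it says the series, first, only, none or still open, it means among the compounds named here.

Measured so far:
- Compound 1, `Cc1nc(C(F)(F)F)ccc1C(=O)Nc1ccc(Cl)c(-c2nc3ccccc3n2C)c1`: 9 nM
- Compound 2, `Cc1nc(C(F)(F)F)ccc1C(=O)Nc1ccc(Cl)c(-c2nc3c(n2C)CCCC3)c1`: 150 nM
- Compound 3, `Cc1nc(C(F)(F)F)ccc1C(=O)Nc1ccc(Cl)c(-c2cn3ccsc3n2)c1`: 200 nM

In an assay on C3H 10T1/2 cells for inhibition of Sonic hedgehog protein (Mus musculus), read by a luciferase reporter (on this read-out higher numbers stand for weaker inhibition and lower numbers for stronger inhibition), compound 3 gives the highest of the three numbers, the weakest inhibition shown. Its nearest neighbour is compound 2; the gap between them a 1.3-fold higher number from compound 2 to compound 3 (0.12 log units; within the scatter) is within the scatter, so the two cannot be told apart. Compound 1 lies far off: a 22-fold higher number from compound 1 to compound 3 (1.35 log units; beyond the scatter), and likewise a 17-fold higher number from compound 1 to compound 2 (1.22 log units; beyond the scatter). Both large steps come from replacing the group that sits on the shared core of compound 1, which is also where compound 4, `Cc1nc(C(F)(F)F)ccc1C(=O)Nc1ccc(Cl)c(C(=O)Nc2ccccc2)c1`, differs from compound 3: a group of 9 heavy atoms (7 carbon, 1 nitrogen, 1 oxygen; one six-membered aromatic ring of carbon only) in place of a group of 8 heavy atoms (5 carbon, 2 nitrogen, 1 sulfur; 2 five-membered aromatic rings with 2 hetero atoms each), on an aromatic carbon. Among the compounds with values here, no measured step swaps in a phenylcarbamoyl group, so there is no direct guide. What the three compounds do show is that the group at this position matters greatly, and that two quite different replacements of the group in compound 1 both gave weak inhibition. A phenylcarbamoyl group is a third, again different, replacement. The expectation for compound 4 in this assay is therefore a number near that of compound 3, with wide uncertainty in both directions: a 2.0-fold higher number from compound 3 to compound 4 (0.30 log units; within the scatter). The estimate for compound 4 is 400 nM, expected to fall between 80 nM and 3000 nM.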

Compound 4, half-maximal inhibitory concentration: 140 nM
Beside the measured number, compound 4's estimate is 2.9-fold (0.46 log units) above it, and the stated range covers the measured number.
By their numbers in this assay, from the lowest: compound 1; then compounds 4, 2 and 3 (each within the scatter of the next).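

In this assay, the step of a 1.4-fold lower number from compound 3 to compound 4 (0.15 log units; within the scatter) and the step of a 1.1-fold lower number from compound 2 to compound 4 (0.03 log units; within the scatter) both lie within the scatter, so phenylcarbamoyl cannot be told apart from the groups in compound 2 and compound 3, even though its atoms and ring differ from theirs. The step of a 16-fold higher number from compound 1 to compound 4 (1.19 log units; beyond the scatter) is large, which makes phenylcarbamoyl the third group at this place, ortho to a chloro group, to stand well away from the 1-methyl-1H-benzimidazol-2-yl of compound 1. The information available offers no explanation for these results.

The compounds shown leave open whether the amide hydrogen of phenylcarbamoyl matters, which a methyl group on the amide nitrogen would test. They also leave open whether a methoxy group or a fluorine on its phenyl ring would move the number towards that of compound 1.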